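A few compounds are considered here, and "the series" means these few. Any claim that something is new, unique, unknown or untested is made for them only; others in the source may bear on it.

Two compounds of the series have numbers in an ADME assay on Huh-7 cells (Homo sapiens) for cytotoxicity, read by colorimetric assay; on this read-out lower numbers stand for higher toxicity in this test and higher numbers for lower toxicity in this test. Compound 1 `COc1ccc2c(O[C@H]3C[C@H]4C(=O)N(C)CCCC/C=C/[C@@H]5C[C@@]5(C(=O)NS(=O)(=O)C5(C)CC5)NC(=O)N4C3)cc(-c3nc(C(C)C)cs3)nc2c1Cl` gives 48500 nM in this assay. Within the data shown here, compound 2 `C#Cc1csc(-c2cc(O[C@H]3C[C@H]4C(=O)N(C)CCCC/C=C/[C@@H]5C[C@@]5(C(=O)NS(=O)(=O)C5(C)CC5)NC(=O)N4C3)c3ccc(OC)c(Cl)c3n2)n1` gives 17000 nM in this assay, which is the lowest of the two numbers, and the single measured step, a 2.9-fold lower number from compound 1 to compound 2 (0.46 log units; beyond the scatter), lies beyond the scatter.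

Compound 3 `C=Cc1csc(-c2cc(O[C@H]3C[C@H]4C(=O)N(C)CCCC/C=C/[C@@H]5C[C@@]5(C(=O)NS(=O)(=O)C5(C)CC5)NC(=O)N4C3)c3ccc(OC)c(Cl)c3n2)n1` differs from compound 2 in one place: vinyl in place of ethynyl on an aromatic carbon. Among the measured compounds shown here, no measured step covers this exchange directly. For the measured compounds named here, the one step that bears on it is the change at the same carbon of the thiazole, a 2.9-fold lower number from compound 1 to compound 2 (0.46 log units; beyond the scatter), in which a branched alkyl group gave way to ethynyl and the number fell by a modest amount. The exchange from ethynyl to vinyl is a smaller alteration than that from isopropyl to ethynyl, so the step in this assay for compound 3 is expected to stay within the scatter or at most to lower the number slightly. Compound 3 is therefore estimated at 19000 nM in this assay, with a range from 8000 nM to 45000 nM. This estimate corresponds to an expected step of a 1.1-fold higher number from compound 2 to compound 3 (0.05 log units; within the scatter).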

Compound 3, half-maximal cytotoxic concentration: 57100 nM
For compound 3 the middle estimate is 3.0-fold (0.48 log units) below the measured one; measured number above the stated range.
By their numbers in this assay, from the lowest: compound 2; then compounds 1 and 3 (each within the scatter of the next).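

In this assay, the exchange of 4-ethynyl-1,3-thiazol-2-yl for 4-vinyl-1,3-thiazol-2-yl gives a 3.4-fold higher number from compound 2 to compound 3 (0.53 log units; beyond the scatter), so replacing the triple bond with a double bond in a group of the same heavy-atom count is enough to produce a step beyond the scatter at this aromatic carbon. The comparison with the isopropyl compound gives a 1.2-fold higher number from compound 1 to compound 3 (0.07 log units; within the scatter), which lies within the scatter: vinyl and isopropyl cannot be told apart here, and the lower number of compound 2 goes with ethynyl specifically rather than with loss of isopropyl as such. No measurement is available that accounts for the separation of ethynyl from the other two groups.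

On these data alone, it remains open whether an ethyl group, a nitrile or a propynyl chain on this carbon would fall with ethynyl or with vinyl and isopropyl. Among these compounds, also open is whether the separation of ethynyl from vinyl holds on a core other than the one shared by these compounds, or with the acyclic counterpart of the macrocyclic linker.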